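Swapping the Dichlorophenyl for Cyclohexyl in a Chalcone-like Acetate

The compounds below may be only part of what the source reports. "The series", "measured", "known", "first", "only" and "open" are said of these compounds alone.

Measured compounds:
compound 1, `COc1ccc(C(=O)/C(=C/C2CCCCC2)COC(C)=O)cc1`, 90000 nM
compound 2, `COc1ccc(C(=O)/C(=C/c2ccc(Cl)cc2Cl)CCOC(C)=O)cc1`, 69200 nM

Both compounds were tested in a functional assay on A549 cells (Homo sapiens) for inhibition, read by XTT assay, with a stated time of 48 h; on this read-out higher numbers stand for weaker inhibition and lower numbers for stronger inhibition. In this assay compound 1 gives 90000 nM, and compound 2 gives 69200 nM. Compound 2 has the lower of the two numbers, but its nearest neighbour, compound 1, sits within the usual scatter of such measurements, so the two cannot be told apart and neither counts as stronger. Both numbers are high, meaning only weak inhibition of the cells.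

Compound 3, `COc1ccc(C(=O)/C(=C/C2CCCCC2)CCOC(C)=O)cc1`, has not yet been measured. It differs from compound 2 in a single place: cyclohexyl in place of 2,4-dichlorophenyl on a double-bonded chain carbon bound to a double-bonded chain carbon. For the measured compounds named here, no measured pair in this set isolates that change, so there is no direct precedent for its size. Because compound 1, which also carries the cyclohexyl, gives 90000 nM in this assay, a value in the same weak region seems most likely, and the expected step from compound 2 to compound 3 is a 1.2-fold higher number from compound 2 to compound 3 (0.09 log units; within the scatter), essentially none beyond the scatter. Compound 3 is therefore estimated at 85000 nM, with a plausible range from 35000 nM to 200000 nM.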

Compound 3, half-maximal inhibitory concentration: > 100000 nM
Compound 3: only a limit was reported; the forecaster's own chance of this, stated with the estimate: 20%; middle value at least 1.1-fold (0.07 log units) from the limit.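

In this assay compound 3 carries only a limit of the assay, not a number: the limit of > 100000 nM in this assay, at which 1 of the 3 values shown sits. Cyclohexyl in place of 2,4-dichlorophenyl on a double-bonded chain carbon bound to a double-bonded chain carbon gives an at least 1.4-fold higher number from compound 2 to compound 3 (0.15 log units; that floor lies within the scatter), the first reading of this swap, and acetoxymethyl in place of acetoxy on a saturated chain carbon bound to a double-bonded chain carbon gives an at least 1.1-fold higher number from compound 1 to compound 3 (0.04 log units; that floor lies within the scatter). For the compounds shown here, both steps are floors rather than sizes, and neither floor clears the scatter, so each change might do almost nothing or might weaken inhibition considerably; the result shows only that neither change brings a gain in inhibition.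

The compounds shown leave open how 2,4-dichlorophenyl behaves with the acetoxy group of compound 1, a pairing that would show whether the two changes act independently. They also leave open whether a different group at this place, such as an unsubstituted phenyl or a ring carrying an amine, or a free hydroxyl in place of the acetate, would bring these high numbers down at all.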